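Urea for cyclobutylamide on the benzimidazole series

The source may hold more compounds than are shown below. What is called first, only, known or untested is meant among the compounds shown, and "the series" means these compounds.

Measured so far:
compound 1 `Cc1cccc(CSc2nc3cc(NC(=O)C4CC4)ccc3n2C(C)C)c1` gives 6500 nM in an assay on isolated protein for inhibition of Gonadotropin-releasing hormone receptor (Homo sapiens); on this read-out higher numbers stand for weaker inhibition and lower numbers for stronger inhibition;
compound 2 `COc1ccc([N+](=O)[O-])cc1CSc1nc2cc(NC(=O)C3CCC3)ccc2n1C(C)C` gives 1500 nM in this assay.

Compound 2 stands at the lower of the two numbers; compound 1 sits above it, and that gap is beyond the scatter. Compound 3 `CNC(=O)Nc1ccc2c(c1)nc(SCc1cc([N+](=O)[O-])ccc1OC)n2C(C)C` carries the change (methylamino in place of cyclobutyl on a carbonyl carbon), methylamino in place of cyclobutyl on a carbonyl carbon. For the measured compounds named here, no measured pair shows this change, so its size is unknown. Compound 3 is expected to give 2500 nM, within 600 nM to 10000 nM. The expected step of a 1.7-fold higher number from compound 2 to compound 3 (0.22 log units; within the scatter) is estimated as a small weakening, close to the scatter.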

Compound 3, half-maximal inhibitory concentration: 3300 nM
Compound 3: the middle estimate sits 1.3-fold (0.12 log units) below what was measured, and the stated range covers the measured number.
By their numbers in this assay, from the lowest: compound 2; then compounds 3 and 1 (each within the scatter of the next).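

In this assay, methylamino in place of cyclobutyl on a carbonyl carbon gives a 2.2-fold higher number from compound 2 to compound 3 (0.34 log units; beyond the scatter), the first single-place change read in this series. At this one pair, the position accepts an open methylamino with a hydrogen-bond donor in place of the four-membered ring at only a modest loss. Nothing at hand accounts for the size of this step. From the compounds shown here alone, whether it follows from losing the ring or from the entering nitrogen stays open. A propyl chain or dimethylamino on the same carbonyl carbon would bear on that question.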